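The source may hold more compounds than are shown below. What is called first, only, known or untested is meant among the compounds shown, and "the series" means these compounds.

Measured compounds in a functional assay on NCI-H460 cells (Homo sapiens) for inhibition, with a stated time of 72 h; a lower number here means a stronger inhibitor, a higher number a weaker inhibitor:
- compound 1, `COc1ccc(S(=O)(=O)N2CCc3cccc(-c4ccc([N+](=O)[O-])cc4)c32)cc1`, gives 53.1 nM
- compound 2, `COc1ccc(S(=O)(=O)N2CCc3cccc(-c4cccnc4)c32)cc1`, gives 89.6 nM
- compound 3, `COc1ccc(S(=O)(=O)N2CCc3cccc(-c4ccc(C#N)cc4)c32)cc1`, gives 29.5 nM

Compound 1 holds the second highest of the three numbers; its nearest neighbour is compound 2, with a 1.7-fold higher number from compound 1 to compound 2 (0.23 log units; within the scatter), and its furthest is compound 3, with a 1.8-fold lower number from compound 1 to compound 3 (0.26 log units; within the scatter). Both of those steps sit within the scatter, so compound 1 is not separated from either. Among the compounds with values here, the one step that clears the scatter is a 3.0-fold lower number from compound 2 to compound 3 (0.48 log units; beyond the scatter).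

Compound 4, `COc1ccc(S(=O)(=O)N2CCc3cccc(-c4ccccc4)c32)cc1`, is not yet measured. It differs from compound 1 by hydrogen in place of nitro on an aromatic carbon. The closest measured precedent is the exchange at the same aromatic carbon from compound 1 to compound 3, which moved the number only within the scatter. The series gives no case where this ring carries only hydrogen, so the effect of simply removing the group is not pinned down. The expectation is therefore a step in this assay of no more than modest size, most likely toward a somewhat higher number, as a 1.7-fold higher number from compound 1 to compound 4 (0.23 log units; within the scatter). Compound 4 is estimated at 90 nM, within 30 nM to 270 nM.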

Compound 4, half-maximal inhibitory concentration: 213 nM
The estimate for compound 4 lay 2.4-fold (0.37 log units) below the measured number; the measured number falls inside the stated range.
By their numbers in this assay, from the lowest: compounds 3, 1 and 2 (each within the scatter of the next, the first and the last beyond it); then compound 4.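

In this assay, a bare phenyl proves clearly less favourable than the substituted rings: removing nitro gives a 4.0-fold higher number from compound 1 to compound 4 (0.60 log units; beyond the scatter), and removing cyano gives a 7.2-fold higher number from compound 3 to compound 4 (0.86 log units; beyond the scatter). The exchange of nitro for cyano had stayed within the scatter, so it could not show that this place on the ring matters; the loss of either group shows that it does, although compound 2 goes against any rule that a substituent is needed, since its unsubstituted pyridin-3-yl ring still gives a 2.4-fold higher number from compound 2 to compound 4 (0.38 log units; beyond the scatter). No measurement at hand accounts for these gaps.

The compounds shown leave open whether groups such as an amine, a carboxylic acid or a fluorine atom at this place would match nitro and cyano or stay nearer to hydrogen. Within the data shown here, with only two substituted phenyl rings, no ordering of groups at this place can yet be drawn.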